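Nucleoside series: thiophen-3-yl for ethynyl, all at limits

This account rests on a few compounds, and the source may have more. Where it says the series, first, only, none or still open, it means among the compounds named here.

Compound 2 `C#Cc1cn([C@@H]2O[C@H](CO)[C@@H](O)[C@H]2O)c2nc(N)nc(OC)c12` carries an ethynyl group on the shared core. In a functional assay on CCRF-CEM cells (Homo sapiens), read by MTT assay, with a stated time of 72 h (a higher number here means a weaker inhibitor, a lower number a stronger inhibitor), compound 2 gives only a limit, > 100000 nM. Compound 1 `COc1nc(N)nc2c1c(-c1ccsc1)cn2[C@@H]1O[C@H](CO)[C@@H](O)[C@H]1O` differs from compound 2 by thiophen-3-yl in place of ethynyl on an aromatic carbon. In this assay compound 1 likewise gives only a limit, > 20000 nM. The step that the two limits leave unreadable from compound 2 to compound 1 therefore cannot be read, because both ends sit at limits, as recorded by the limit of > 100000 nM in this assay, at which 1 of the 3 values shown sits, and (the limit of > 20000 nM in this assay, at which 2 of the 3 values shown sit).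

Compound 3 `C#Cc1cn([C@@H]2O[C@H](CO)[C@@H](O)[C@H]2O)c2ncnc(SC)c12` keeps the ethynyl group but on a second core; the difference between the two cores is not broken down here. In this assay compound 3 gives only a limit, > 20000 nM. Compound 4 `CSc1ncnc2c1c(-c1ccsc1)cn2[C@@H]1O[C@H](CO)[C@@H](O)[C@H]1O` is not yet measured and differs from compound 3 by thiophen-3-yl in place of ethynyl on an aromatic carbon, the same change that turns compound 2 into compound 1.

No measured value in the set is a number; every result is a limit, so no pattern can be drawn from the three compounds shown. The expectation for compound 4 rests only on this: the same change left compound 1 at a limit, and compound 3 starts from one. The step from compound 3 to compound 4 is estimated to be about a step that the limit leaves unreadable from compound 3 to compound 4, which is to say no readable change. Compound 4 is expected to give roughly 40000 nM in this assay, most likely reported again as a limit, within the range 10000 nM to 200000 nM.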

Compound 4, half-maximal inhibitory concentration: > 20000 nM
Compound 4: only a limit was reported; the forecaster's own chance of this, stated with the estimate: 85%; the middle value lies beyond the limit too.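

In this assay compound 4 gives only a limit, as compound 3 does, so the step between compound 3 and compound 4 cannot be read, and the thiophen-3-yl for ethynyl change again yields no size: the limit of > 20000 nM in this assay, at which 3 of the 4 values shown sit.

The compounds shown leave open whether this change alters potency at all in this assay on either core, with all four results being limits and none a number.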